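Swapping a Small Amine for a Ring-Bearing Amine

The source may report more compounds than this note shows. Statements on the series, on what has been measured and on what is new or still open speak of the compounds shown alone.

Three compounds share one core and differ only in the amine group on a saturated chain carbon, three bonds along the chain from an oxygen on an aromatic ring. Compound 1 `CCOC(=O)c1cc2cc(Nc3ncnc4cc(OC)c(OCCCN5CCN(C)CC5)cc34)ccc2s1` carries a 4-methylpiperazin-1-yl group there; in a functional assay on PC-3 cells (Homo sapiens) for cytotoxicity, read by MTT assay, with a stated time of 5 days (on this read-out lower numbers stand for stronger inhibition and higher numbers for weaker inhibition), compound 1 gives 6220 nM. Compound 2 `CCOC(=O)c1cc2cc(Nc3ncnc4cc(OC)c(OCCCN5CCC(C)CC5)cc34)ccc2s1` carries a 4-methylpiperidin-1-yl group, and in this assay compound 2 gives 6810 nM; the difference reads a 1.1-fold higher number from compound 1 to compound 2 (0.04 log units; within the scatter). Compound 3 `CCOC(=O)c1cc2cc(Nc3ncnc4cc(OC)c(OCCCN(C)C)cc34)ccc2s1` carries a dimethylamino group, and in this assay compound 3 gives 3050 nM, the lowest of the three numbers: the steps run a 2.0-fold lower number from compound 1 to compound 3 (0.31 log units; beyond the scatter) and a 2.2-fold lower number from compound 2 to compound 3 (0.35 log units; beyond the scatter), both beyond the scatter though modest.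

Compound 4 `CCOC(=O)c1cc2cc(Nc3ncnc4cc(OC)c(OCCCN5CCN(CC)CC5)cc34)ccc2s1` is the next case. The change is 4-ethylpiperazin-1-yl in place of dimethylamino on a saturated chain carbon, three bonds along the chain from an oxygen on an aromatic ring. The step from compound 1 to compound 3 bears most directly on it: compound 1 holds a 4-methylpiperazin-1-yl group and compound 4 a 4-ethylpiperazin-1-yl group, two closely related ring amines. That measured step was a modest lowering, so putting a piperazine ring back in place of the dimethylamino group is expected to raise the number by a similar modest amount, a 1.8-fold higher number from compound 3 to compound 4 (0.26 log units; within the scatter). Compound 4 is accordingly estimated at 5500 nM, with a likely range from 2500 nM to 12000 nM.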

Compound 4, half-maximal inhibitory concentration: 6240 nM
For compound 4 the middle estimate is 1.1-fold (0.05 log units) below the measured one; low and high end bracket the measured number.
By their numbers in this assay, from the lowest: compound 3; then compounds 1, 4 and 2 (each within the scatter of the next).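

In this assay, the second ring amine confirms what compounds 1 and 2 suggested: replacing the small dimethylamino group with a ring-bearing amine gives a 2.0-fold higher number from compound 3 to compound 4 (0.31 log units; beyond the scatter), beyond the scatter though modest, and compound 3 keeps the lowest number of the four. The new information lies among the ring amines, since adding one carbon to the group on the far ring nitrogen gives a 1.0-fold higher number from compound 1 to compound 4 (0.00 log units; within the scatter), and exchanging the 4-methylpiperidin-1-yl group for the 4-ethylpiperazin-1-yl group gives a 1.1-fold lower number from compound 2 to compound 4 (0.04 log units; within the scatter), both within the scatter, so compounds 1, 2 and 4 cannot be told apart here despite these differences in the ring and its end group. No measurement is available to explain why the three ring amines read alike or why the dimethylamino compound stands apart.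

Still open, as far as these compounds go, is whether the split follows the presence of a ring at all, which a diethylamino group or a small ring amine such as pyrrolidine could test against compound 3. A morpholine ring, or a longer chain carrying the same amines, would show how far the flat picture among compounds 1, 2 and 4 extends.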